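Swapping the Methyl Aglycone of Compound 1 for Phosphate

The source may report more compounds than this note shows. Statements on the series, on what has been measured and on what is new or still open speak of the compounds shown alone.

The three compounds measured here share one sugar-like core and differ only in the group attached to its oxygen. Compound 1, `COC1SC(C)C(O)C(O)C1O`, is the weakest of the three in an assay on isolated protein for inhibition of tissue alpha-L-fucosidase (Homo sapiens) (on this read-out higher numbers stand for weaker inhibition and lower numbers for stronger inhibition), where compound 1 gives 690000 nM. Compound 2, `CC1SC(Oc2ccc([N+](=O)[O-])cc2)C(O)C(O)C1O`, carries a nitrophenyl group joined through oxygen and gives 118000 nM in this assay. Compound 3, `CC1SC(Sc2ccc([N+](=O)[O-])cc2)C(O)C(O)C1O`, carries the same nitrophenyl group joined through sulfur and gives 3300 nM in this assay. Both gaps from compound 1 lie beyond the scatter, so the group on that side of the core clearly matters.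

Compound 4, `CC1SC(OP(=O)(O)O)C(O)C(O)C1O`, has not yet been measured. It differs from compound 1 as follows: a group of 4 heavy atoms (3 oxygen, 1 phosphorus; no ring) in place of one carbon atom, on an oxygen on a saturated carbon. The methyl gives way to a phosphate.

For the measured compounds named here, no measured pair shows this exact change, so the expectation rests only on the fact that every change to the aglycone seen so far has lowered the number. The step from compound 1 to compound 4 is expected to be a 3.5-fold lower number from compound 1 to compound 4 (0.54 log units; beyond the scatter), a modest move toward stronger inhibition, though a result within the scatter would not surprise. Compound 4 is therefore estimated at 200000 nM in this assay, with a range from 30000 nM to 1500000 nM.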

Compound 4, inhibition constant: 406000 nM
Beside the measured number, compound 4's estimate is 2.0-fold (0.31 log units) below it; the measured number falls inside the stated range.
By their numbers in this assay, from the lowest: compound 3; then compound 2; then compounds 4 and 1 (each within the scatter of the next).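

In this assay, replacing the methyl with the phosphate gives a 1.7-fold lower number from compound 1 to compound 4 (0.23 log units; within the scatter), so this change does not separate compound 4 from compound 1. For the compounds shown here, the earlier compounds showed only that the number can fall well beyond the scatter at this place, with compound 2 at 118000 nM and compound 3 at 3300 nM; compound 4 shows that a change here need not move the number at all, even though the entering group brings more heavy atoms and hydrogen-bond donors than the methyl it replaces. Nothing in the available data explains why the phosphate leaves the read-out within the scatter of the methyl.

Going by these compounds alone, no compound measured so far carries a plain phenyl group on the same oxygen. Measuring one would show whether the number stays level with that of compound 2 without the nitro group. As far as these compounds go, it is also open whether a carboxylic acid or a longer chain such as ethyl would stay level with compound 1, as the phosphate does, or move the number as the nitrophenyl groups do.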